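Series notes: anilide change on the benzyl-bearing core

The source may report more compounds than this note shows. Statements on the series, on what has been measured and on what is new or still open speak of the compounds shown alone.

Among the compounds with values here, compound 2 `Cc1ccc(F)cc1NC(=O)CN1CCN(c2nnc(Cc3ccccc3)c3ccccc23)CC1` stands at the top of the three numbers measured so far: in a functional assay on HT-29 cells (Homo sapiens) for cytotoxicity, read by MTT assay, with a stated time of 72 h (a higher number here means a weaker inhibitor, a lower number a stronger inhibitor), compound 2 gives 171000 nM, against compound 1 `O=C(CN1CCN(c2nnc(Cc3ccncc3)c3ccccc23)CC1)Nc1ccc(Br)cc1` at 1990 nM and compound 3 `O=C(CN1CCN(c2nnc(Cc3ccncc3)c3ccccc23)CC1)Nc1cccc(Br)c1` at 1350 nM, both gaps beyond the scatter. Compound 1 and compound 3 differ from compound 2 in two places at once, so their distance from compound 2 cannot be split into parts.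

Compound 4 `O=C(CN1CCN(c2nnc(Cc3ccccc3)c3ccccc23)CC1)Nc1ccc(F)c(Cl)c1` keeps the core of compound 2 and changes only the anilide ring: 3-chloro-4-fluorophenyl in place of 5-fluoro-2-methylphenyl on an amide-type nitrogen. Within the data shown here, the only measured single step, a 1.5-fold lower number from compound 1 to compound 3 (0.17 log units; within the scatter), moves a bromine around an anilide ring on a different core and stays within the scatter, so it gives no direct guide to removing a methyl and adding a chlorine. The far lower numbers of compound 1 and compound 3, whose anilide rings lack the methyl of compound 2, suggest compound 4 is expected to fall below compound 2, by about a 5.7-fold lower number from compound 2 to compound 4 (0.76 log units; beyond the scatter), though with wide uncertainty. Compound 4 is therefore estimated at 30000 nM, within 5000 nM to 180000 nM.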

Compound 4, half-maximal inhibitory concentration: 13300 nM
Beside the measured number, compound 4's estimate is 2.3-fold (0.35 log units) above it; low and high end bracket the measured number.
By their numbers in this assay, from the lowest: compounds 3 and 1 (each within the scatter of the next); then compound 4; then compound 2.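

In this assay, the anilide ring on the amide-type nitrogen proves to be a sensitive position on the core of compound 2: 3-chloro-4-fluorophenyl in place of 5-fluoro-2-methylphenyl gives a 13-fold lower number from compound 2 to compound 4 (1.11 log units; beyond the scatter), with the core held fixed and both groups counting 8 heavy atoms. Within the data shown here, the earlier single step, a 1.5-fold lower number from compound 1 to compound 3 (0.17 log units; within the scatter), showed no change beyond the scatter at this ring, so this is the first step showing that the ring can move the number substantially. Nothing available explains the size of this step.

The swap removes the methyl, adds the chlorine and relocates the fluorine at once, so the share of each remains unresolved. Also open, going by these compounds, are how a methoxy or nitrile group on this ring would read, and whether the 3-chloro-4-fluorophenyl group would give a similar step on the core of compound 1.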